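Swapping Chloro for Trifluoromethyl in Compound 2

The source may hold more compounds than are shown below. What is called first, only, known or untested is meant among the compounds shown, and "the series" means these compounds.

Three compounds sharing one core have been tested in a functional assay on HepG2 cells (Homo sapiens) for antiproliferative activity, read by CCK-8 assay, with a stated time of 72 h; on this read-out higher numbers stand for weaker inhibition and lower numbers for stronger inhibition:
Compound 1, `O=C(Nc1cccc(-c2oc3cc(-c4ccc(F)cc4)ccc3c(=O)c2O)c1)c1ccccc1F`, gives 10100 nM.
Compound 2, `O=C(Nc1cccc(-c2oc3cc(-c4ccc(F)cc4)ccc3c(=O)c2O)c1)c1ccc(Cl)cc1`, gives 11000 nM.
Compound 3, `Cc1ccccc1C(=O)Nc1cccc(-c2oc3cc(-c4ccc(F)cc4)ccc3c(=O)c2O)c1`, gives 19400 nM.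

Compound 2 stands second highest of these three numbers. Its nearest neighbour is compound 1, separated by a 1.1-fold higher number from compound 1 to compound 2 (0.04 log units; within the scatter), and its furthest is compound 3, reached by a 1.8-fold higher number from compound 2 to compound 3 (0.25 log units; within the scatter). Both steps stay within the scatter, so the three measured amide rings cannot be told apart in this assay.

Compound 4, `O=C(Nc1cccc(-c2oc3cc(-c4ccc(F)cc4)ccc3c(=O)c2O)c1)c1ccc(C(F)(F)F)cc1`, is compound 2 with a single change: trifluoromethyl in place of chloro on an aromatic carbon. Among the measured compounds shown here, the steps that bear on this change are the two just described, a 1.1-fold higher number from compound 1 to compound 2 (0.04 log units; within the scatter) and a 1.8-fold higher number from compound 2 to compound 3 (0.25 log units; within the scatter), each altering the same amide ring and each remaining within the scatter. No change at this spot has yet moved the number beyond the scatter, so none is expected here either. The estimate for compound 4 therefore means a step of a 1.0-fold higher number from compound 2 to compound 4 (0.02 log units; within the scatter) in this assay. Compound 4 is expected to give 11500 nM, in a range from 5000 nM to 26000 nM.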

Compound 4, half-maximal inhibitory concentration: 42700 nM
Beside the measured number, compound 4's estimate is 3.7-fold (0.57 log units) below it; the whole stated range lies below it.
By their numbers in this assay, from the lowest: compounds 1, 2 and 3 (each within the scatter of the next); then compound 4.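

In this assay, among the compounds shown here, this place on the amide ring is not as insensitive as the earlier compounds suggested: trifluoromethyl in place of chloro gives a 3.9-fold higher number from compound 2 to compound 4 (0.59 log units; beyond the scatter), the first step from compound 2 at this ring to leave the scatter. Compound 4 also separates from the other two amide rings, with a 2.2-fold higher number from compound 3 to compound 4 (0.34 log units; beyond the scatter) and a 4.2-fold higher number from compound 1 to compound 4 (0.63 log units; beyond the scatter), which makes it the weakest inhibitor of the four, though each of these steps is only modest. Nothing available gives a reason for this loss of activity.

From the compounds shown here alone, it remains open whether the loss is particular to trifluoromethyl or would also appear with another group at the same place, such as a methoxy group, a nitrile or an amine. Going by these compounds, a carboxylic acid there is equally open.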